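The compounds below may be only part of what the source reports. "The series", "measured", "known", "first", "only" and "open" are said of these compounds alone.

In a functional assay on SGC-7901 cells (Homo sapiens) for antiproliferative activity, read by MTT assay, with a stated time of 72 h (on this read-out lower numbers stand for stronger inhibition and higher numbers for weaker inhibition), compound 1 `COc1ccc(-c2ccc3ncn(-c4cc(OC)c(OC)c(OC)c4)c3c2)cc1O` gives 44 nM. Compound 2 `COc1ccc(-c2ccc3ncn(-c4cc(OC)c(OC)c(OC)c4)c3c2)cc1F` gives 430 nM, and the change between them is fluoro in place of hydroxy on an aromatic carbon, a step of a 9.8-fold higher number from compound 1 to compound 2 (0.99 log units; beyond the scatter). Compound 3 `COc1cc(-n2cnc3ccc(-c4ccc(O)cc4)cc32)cc(OC)c1OC` carries a different group on the shared core, (4-hydroxyphenyl in place of 3-hydroxy-4-methoxyphenyl on an aromatic carbon). For compound 3 this assay reports only a limit, > 10000 nM, so the step from compound 1 is an at least 220-fold higher number from compound 1 to compound 3 (2.35 log units; beyond the scatter) and the step from compound 2 is an at least 23-fold higher number from compound 2 to compound 3 (1.36 log units; beyond the scatter) (the limit of > 10000 nM in this assay, at which 1 of the 3 values shown sits). Compound 4 `COc1cc(-n2cnc3ccc(-c4ccc(F)cc4)cc32)cc(OC)c1OC` is not yet measured; it differs from compound 3 by fluoro in place of hydroxy on an aromatic carbon. This is the same kind of change as that from compound 1 to compound 2, though there the fluoro sits ortho to a methoxy group and meta to a large group, whereas here it sits para to a large group. Since the earlier step was a 9.8-fold higher number from compound 1 to compound 2 (0.99 log units; beyond the scatter) and compound 3 gives only a limit, compound 4 is expected to stay at or beyond that limit, a step that the limit leaves unreadable from compound 3 to compound 4. The estimate for compound 4 is 25000 nM, between 6000 nM and 120000 nM.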

Compound 4, half-maximal inhibitory concentration: 3500 nM
Compound 4: middle estimate off by 7.1-fold (0.85 log units), on the high side; the measured number lies below the stated range.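

The same swap of hydroxy for fluoro does not carry over between these two cores in this assay, where it raises the number on one core and lowers it on the other: the same change on two cores in this assay, a 9.8-fold higher number (0.99 log units; beyond the scatter) from compound 1 to compound 2 and an at least 2.8-fold lower number (0.45 log units; beyond the scatter) from compound 3 to compound 4, at least 27-fold (1.44 log units) apart, beyond the scatter of two such steps. Compound 3 gives > 10000 nM, which is a limit and not a number, so an at least 2.8-fold lower number from compound 3 to compound 4 (0.45 log units; beyond the scatter) fixes only the direction and a minimum size. There is an 8.1-fold higher number from compound 2 to compound 4 (0.91 log units; beyond the scatter) and an 80-fold higher number from compound 1 to compound 4 (1.90 log units; beyond the scatter), so the 4-fluorophenyl group still trails both groups that carry a methoxy, but two cores cannot show how the swap behaves on any further core.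

The compounds shown leave open whether an amine or a chloro group, para to a large group, would track compound 3 or compound 4. They also do not explain why the swap differs between the two cores.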